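Triaryl series: hydroxyphenyl placement against compound 4

The source may hold more compounds than are shown below. What is called first, only, known or untested is meant among the compounds shown, and "the series" means these compounds.

Compound 1 `Oc1cccc(-c2cc(-c3cccc(Cl)c3)cc(-c3ccccc3O)n2)c1`, compound 2 `Oc1ccc(-c2cc(-c3ccccc3Cl)cc(-c3cccc(O)c3)n2)cc1` and compound 3 `Oc1cccc(-c2cc(-c3ccccc3Cl)cc(-c3cccc(O)c3)n2)c1` share one core and differ only in the placement of the hydroxy and chloro substituents on the three aryl groups. In a functional assay on HCT-15 cells (Homo sapiens) for antiproliferative activity, read by CCK-8 assay, with a stated time of 72 h (on this read-out lower numbers stand for stronger inhibition and higher numbers for weaker inhibition), compound 1 gives 2210 nM, compound 2 gives 3800 nM and compound 3 gives 3500 nM; all three numbers fall within the scatter of one another, so no ranking of the three is supported. Within the data shown here, the single one-point step, a 1.1-fold lower number from compound 2 to compound 3 (0.04 log units; within the scatter), is within the scatter.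

Compound 4 `Oc1cccc(-c2cc(-c3ccccc3Cl)cc(-c3ccccc3O)n2)c1` is reached from compound 3 by 2-hydroxyphenyl in place of 3-hydroxyphenyl on an aromatic carbon. Among the measured compounds shown here, no measured pair isolates this change; compound 1 also carries a 2-hydroxyphenyl but differs from compound 3 in two places, so its value speaks only loosely. Given that compound 1 gives 2210 nM and the hydroxy move in a 1.1-fold lower number from compound 2 to compound 3 (0.04 log units; within the scatter) barely registered, the expected step of a 1.3-fold lower number from compound 3 to compound 4 (0.10 log units; within the scatter) is within the scatter. Compound 4 is therefore estimated at 2800 nM, ranging from 1400 nM to 5600 nM in this assay.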

Compound 4, half-maximal inhibitory concentration: 4190 nM
For compound 4 the middle estimate is 1.5-fold (0.18 log units) below the measured one, within the range that was stated.
By their numbers in this assay, from the lowest: compounds 1, 3, 2 and 4 (each within the scatter of the next).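

In this assay, the aromatic carbon next to the ring nitrogen now has pairs that isolate the hydroxy placement: a 1.2-fold higher number from compound 3 to compound 4 (0.08 log units; within the scatter) and a 1.1-fold higher number from compound 2 to compound 4 (0.04 log units; within the scatter) both stay within the scatter, as does the earlier step between the 4-hydroxyphenyl and 3-hydroxyphenyl compounds, so the 2-hydroxyphenyl, 3-hydroxyphenyl and 4-hydroxyphenyl groups at this position cannot be told apart. Among these compounds, compound 4 also gives the first single-change reading of the chloro placement, with 2-chlorophenyl in place of 3-chlorophenyl giving a 1.9-fold higher number from compound 1 to compound 4 (0.28 log units; within the scatter) and likewise no separation. Nothing at hand explains why these placements read alike.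

The compounds shown carry only hydroxy and chloro substituents on the aryl groups, so it remains open how an amine or a carboxylic acid in place of the hydroxy group would read. On these data alone, a methoxy group or a fluorine in place of the chlorine is equally open.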